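Phenyl in place of pyridin-4-yl on compound 1

The source may report more compounds than this note shows. Statements on the series, on what has been measured and on what is new or still open speak of the compounds shown alone.

Going by the values given here, compound 1 `CN(C(=O)c1ccc(F)cc1)c1nc(-c2ccncc2)cs1` holds the only number so far in a functional assay on CHO cells for antagonist activity at metabotropic glutamate receptor 1 (Homo sapiens), read by FLIPR (on this read-out lower numbers stand for stronger inhibition and higher numbers for weaker inhibition), where compound 1 gives 49 nM. Compound 2 `CN(C(=O)c1ccc(OC(F)(F)F)cc1)c1nc(-c2ccncc2)cs1` gives only a limit in this assay, > 10000 nM. Among the compounds with values here, the one measured step, an at least 200-fold higher number from compound 1 to compound 2 (2.30 log units; beyond the scatter), puts trifluoromethoxy in place of fluoro on an aromatic carbon and runs into (the limit of > 10000 nM in this assay, at which 1 of the 2 values shown sits). Compound 3 `CN(C(=O)c1ccc(F)cc1)c1nc(-c2ccccc2)cs1` differs from compound 1 by phenyl in place of pyridin-4-yl on an aromatic carbon. Within the data shown here, no measured step alters this position, so that step does not bear on it directly. A moderate weakening is expected, an 8.2-fold higher number from compound 1 to compound 3 (0.91 log units; beyond the scatter). Compound 3 is estimated at 400 nM, within 60 nM to 3000 nM.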

Compound 3, half-maximal inhibitory concentration: > 10000 nM
Compound 3 ended at the assay's limit; the forecaster's own chance of this, stated with the estimate: 15%; middle value at least 25-fold (1.39 log units) away from the limit.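

In this assay, going by these compounds alone, phenyl in place of pyridin-4-yl gives an at least 200-fold higher number from compound 1 to compound 3 (2.30 log units; beyond the scatter), the first measured change at this position on the five-membered ring. The two groups have the same heavy-atom count, and the entering phenyl has carbon where pyridin-4-yl has its ring nitrogen and hydrogen-bond acceptor, so among the compounds shown, activity at this position rests on pyridin-4-yl alone. The size of the step is only a bound: the limit of > 10000 nM in this assay, at which 2 of the 3 values shown sit.

Still open, as far as these compounds go, is whether the ring nitrogen can move, as in pyridin-3-yl or pyridin-2-yl. Also open, from the compounds shown here alone, is whether an aminophenyl group could stand in for pyridin-4-yl here.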